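The compounds below may be only part of what the source reports. "The series", "measured", "known", "first", "only" and "open" are said of these compounds alone.

Compounds measured:
compound 1 `CCOC(=O)CO/N=C(/c1ccc(OC)c(OC)c1OC)c1cccc2ccccc12` — 3360 nM
compound 2 `COc1ccc(/C(=C\c2ccc(F)cc2)c2cccc3ccccc23)c(OC)c1OC` — > 20000 nM

Going by the values given here, compound 1 carries the only finite number in a functional assay on HCT-116 cells (Homo sapiens) for inhibition, read by sulforhodamine B assay, with a stated time of 48 h (on this read-out higher numbers stand for weaker inhibition and lower numbers for stronger inhibition), where compound 1 gives 3360 nM. Compound 2, which replaces the oxime with an alkene to a fluorophenyl group, reports only a limit in this assay, > 20000 nM; (the limit of > 20000 nM in this assay, at which 1 of the 2 values shown sits). Compound 3 `COc1ccc(/C(=N/OC(C)=O)c2cccc3ccccc23)c(OC)c1OC` keeps the core of compound 1 and differs by acetyl in place of (ethoxycarbonyl)methyl on an oxygen. Among the compounds with values here, no measured pair shows this kind of change, so the expected step from compound 1 to compound 3, a 1.1-fold lower number from compound 1 to compound 3 (0.05 log units; within the scatter), is set close to none beyond the scatter. Compound 3 is therefore estimated at 3000 nM, within 800 nM to 12000 nM.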

Compound 3, half-maximal inhibitory concentration: 4980 nM
Estimate against measurement, compound 3: 1.7-fold (0.22 log units) below; the range from low to high includes it.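

Acetyl in place of (ethoxycarbonyl)methyl on this oxygen gives a 1.5-fold higher number from compound 1 to compound 3 (0.17 log units; within the scatter) in this assay. At this position, then, the two groups cannot be told apart in this assay, although acetyl is the smaller by the heavy atom count. The data shown offer no reason for this.

From the compounds shown here alone, what remains open is whether this tolerance extends beyond these two groups: a carboxylic acid, an amine or a longer chain on the same oxygen could still move the number. A single pair also cannot show how far the result holds on other cores.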